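The source may hold more compounds than are shown below. What is called first, only, known or untested is meant among the compounds shown, and "the series" means these compounds.

Measured compounds and values:

compound 1 `N/C(=N\NC(=S)N1CCCC1)c1ccc(F)cn1`: 72.2%
compound 2 `N/C(=N\NC(=S)N1CCSCC1)c1ccc(F)cn1`: 61.2%
compound 3 `N/C(=N\NC(=S)N1CCOCC1)c1ccc(F)cn1`: 47%

In a functional assay on A-431 cells (Homo sapiens) for cytotoxicity, read by MTT assay, with a stated time of 72 h, tested at 3 uM (a lower number here means less inhibition of growth, a higher number more inhibition of growth at the concentration tested), compound 1 stands highest of the three numbers. The other two fall away from it: a number 11 percentage points lower from compound 1 to compound 2 (beyond the scatter) and a number 25.2 percentage points lower from compound 1 to compound 3 (beyond the scatter), while a number 14.2 percentage points lower from compound 2 to compound 3 (beyond the scatter). Every one of these steps exchanges the ring on the thiocarbonyl carbon and leaves the fluorinated ring untouched. Compound 4 `N/C(=N\NC(=S)N1CCCC1)c1ccccn1` differs from compound 1 in another place altogether: hydrogen in place of fluoro on an aromatic carbon. Going by the values given here, no measured step bears on this change, so no direction can be read from the data, and a step of a number 6.2 percentage points lower from compound 1 to compound 4 (within the scatter) is expected, which stays within the usual scatter. Compound 4 is therefore estimated at 66%, with a range from 46% to 84%.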

Compound 4, percent growth inhibition at one concentration: 70.9%
The estimate for compound 4 lay 4.9 percentage points below the measured number; measured number inside the range.
By their numbers in this assay, from the lowest: compound 3; then compounds 2, 4 and 1 (each within the scatter of the next, the first and the last beyond it).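

In this assay the exchange of fluoro for hydrogen gives a number 1.3 percentage points lower from compound 1 to compound 4 (within the scatter) and so stays within the scatter. Unlike the ring exchanges on the thiocarbonyl carbon, this change on the aromatic carbon para to a large group leaves the reading essentially unmoved, at least with pyrrolidin-1-yl in place. Nothing available explains this result. From the compounds shown here alone, whether a chloro, methoxy or amine group at this position would behave alike remains open, as does whether the same exchange would hold with the morpholin-4-yl ring of compound 3.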